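A few compounds are considered here, and "the series" means these few. Any claim that something is new, unique, unknown or untested is made for them only; others in the source may bear on it.

Measured in a functional assay on K562 cells (Homo sapiens) for inhibition, read by fluorescence, with a stated time of 72 h; a lower number here means a stronger inhibitor of growth, a higher number a weaker inhibitor of growth:

- Compound 1, `COc1ccc(Nc2nc(N[C@H]3CC[C@H](N)CC3)nc3c2ncn3CCC(C)C)c(OC)c1`: 5500 nM
- Compound 2, `CC(C)=CCn1cnc2c(Nc3cccc(Cl)c3)nc(N[C@H]3CC[C@H](N)CC3)nc21`: 3500 nM
- Compound 3, `CCCCn1cnc2c(NCc3cccc(Cl)c3)nc(N[C@H]3CC[C@H](N)CC3)nc21`: 4300 nM

These three values lie within the usual scatter of one another, so compound 1, at 5500 nM, cannot be separated from the other two. In this series, none of the three can be called stronger or weaker than the rest.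

The next compound to be tested is compound 4, `COc1cc(Nc2nc(N[C@H]3CC[C@H](N)CC3)nc3c2ncn3CCC(C)C)cc(OC)c1`. For the measured compounds named here, it keeps the shared core of compound 1 and the same chain, and changes only one group: 3,5-dimethoxyphenyl in place of 2,4-dimethoxyphenyl on a nitrogen on an aromatic ring. The atoms are the same, but they are joined differently.

Going by the values given here, no two measured compounds differ in just one place, so the data give no direct measure of a change like this one. Among the compounds with values here, the only guide is indirect. Compound 2 and compound 3 differ from compound 1 in both the group on that nitrogen and the chain on the core, yet compound 2 gives 3500 nM and compound 3 gives 4300 nM. A much smaller edit is therefore expected to produce no shift beyond the scatter, and no clear direction can be predicted.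

The expected step is a 1.4-fold lower number from compound 1 to compound 4 (0.14 log units; within the scatter). For compound 4 the estimated value is 4000 nM, with an expected range from 1500 nM to 10000 nM.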

Compound 4, concentration for 50% growth inhibition: 2500 nM
Beside the measured number, compound 4's estimate is 1.6-fold (0.20 log units) above it; the range from low to high includes it.
By their numbers in this assay, from the lowest: compounds 4, 2, 3 and 1 (each within the scatter of the next, the first and the last beyond it).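

For the compounds shown here, compound 1 and compound 4 are the only pair here that differ in just one place, so they give the first direct reading of a change on this nitrogen on an aromatic ring: in this assay, replacing 2,4-dimethoxyphenyl with 3,5-dimethoxyphenyl gives a 2.2-fold lower number from compound 1 to compound 4 (0.34 log units; beyond the scatter), a modest step, but one that lies beyond the usual scatter. The two groups have the same heavy atoms, the same aromatic ring and the same counts of hydrogen-bond donors and acceptors, so those counts cannot separate them, and the step goes with the arrangement of the two methoxy groups on the ring. The information available offers no measured explanation for this step.

From the compounds shown here alone, it remains open whether one methoxy group or both matter, a question that a plain phenyl, 3-methoxyphenyl or 2-methoxyphenyl on the same nitrogen could help answer. Going by these compounds, it is also open whether the same change would give a similar step with a different chain on the core, such as the butyl chain of compound 3, or whether larger ethoxy groups would extend it.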